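Swapping phenyl for pyridin-3-yl on a hydroxamic acid

The source may hold more compounds than are shown below. What is called first, only, known or untested is meant among the compounds shown, and "the series" means these compounds.

Measured so far:
compound 1, `O=C(NO)c1cccc(OCc2ccc(-c3cccnc3)cc2)c1`, 52300 nM
compound 2, `COc1ccc(C(=O)NO)cc1OCc1ccc(-c2ccccc2)cc1`, 3630 nM

Both compounds were tested in an assay on isolated protein for inhibition of sphingomyelin phosphodiesterase (Homo sapiens), read by fluorescence, with a stated time of 30 min; a higher number here means a weaker inhibitor, a lower number a stronger inhibitor. Compound 1 gives 52300 nM, and compound 2 gives 3630 nM, the lower of the two numbers, a gap beyond the usual scatter. Compound 3, `COc1ccc(C(=O)NO)cc1OCc1ccc(-c2cccnc2)cc1`, has not been measured yet. It differs from compound 2 in one place: pyridin-3-yl in place of phenyl on an aromatic carbon. Going by the values given here, no pair of measured compounds differing in just this way exists, so the size of the step has no direct precedent here. Compound 1 also carries pyridin-3-yl, but it differs from compound 2 in more than this one place, so its weaker number cannot be laid to this change alone. In this assay compound 3 is expected to land near compound 2, at 6000 nM, within 2000 nM to 20000 nM. The expected step from compound 2 to compound 3 is a 1.7-fold higher number from compound 2 to compound 3 (0.22 log units; within the scatter), a modest weakening at most.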

Compound 3, half-maximal inhibitory concentration: 4970 nM
Compound 3: the middle estimate sits 1.2-fold (0.08 log units) above what was measured, within the range that was stated.
By their numbers in this assay, from the lowest: compounds 2 and 3 (each within the scatter of the next); then compound 1.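

Pyridin-3-yl in place of phenyl on this aromatic carbon, para to a large group, gives a 1.4-fold higher number from compound 2 to compound 3 (0.14 log units; within the scatter), so the two groups cannot be told apart in this pair. Compound 1 and compound 3 both carry pyridin-3-yl, and methoxy in place of hydrogen on an aromatic carbon gives an 11-fold lower number from compound 1 to compound 3 (1.02 log units; beyond the scatter), which ties the large gap in that pair to the methoxy change and not to the ring swap. Nothing measured here explains why either step has the size it has.

Among the compounds shown, this position holds only phenyl and pyridin-3-yl, so it stays open whether pyridin-4-yl or a phenyl bearing a carboxylic acid or an amine would give a similar number. On these data alone, it also stays open whether ethoxy would match methoxy.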